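The source may report more compounds than this note shows. Statements on the series, on what has been measured and on what is new or still open speak of the compounds shown alone.

Going by the values given here, compound 1 `CCOc1ccc(NC2=CC(=O)c3ncsc3C2=O)cc1` is the only member of this set with a number attached: in a functional assay on HepG2 cells (Homo sapiens) for cytotoxicity, read by MTT assay (on this read-out higher numbers stand for weaker inhibition and lower numbers for stronger inhibition), compound 1 gives 23.6 ug/mL. Compound 2 `COC1=CC(=O)c2ncsc2C1=O` has no number in this assay; for compound 2 the entry reads "not tested" (no result reported). Compound 3 `O=C1C=C(Nc2ccc(F)cc2)C(=O)c2scnc21` differs from compound 1 by fluoro in place of ethoxy on an aromatic carbon. Among the compounds with values here, no measured step between related compounds is available to guide the expectation, so the change is expected to be small and of no certain direction: the estimated step in this assay is a 1.2-fold lower number from compound 1 to compound 3 (0.07 log units; within the scatter), within the usual scatter. Compound 3 is accordingly expected to give 20 ug/mL in this assay, with a range from 7 ug/mL to 55 ug/mL.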

Compound 3, half-maximal inhibitory concentration: 17.9 ug/mL
The estimate for compound 3 lay 1.1-fold (0.05 log units) above the measured number; the range from low to high includes it.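

In this assay, fluoro in place of ethoxy on an aromatic carbon, para to a large group, gives a 1.3-fold lower number from compound 1 to compound 3 (0.12 log units; within the scatter). This first measured step shows that, at this position, the read-out does not separate these two groups, even though fluoro is the smaller by heavy-atom count. No measured evidence bears on this result.

On these data alone, it remains open whether an amine, a carboxylic acid or a longer alkoxy chain at this position would move the number beyond the scatter. As far as these compounds go, the effect of changes to the shared core also remains open.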